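The source may hold more compounds than are shown below. What is called first, only, known or untested is meant among the compounds shown, and "the series" means these compounds.

Measured compounds:
Compound 1, `CC(=O)Oc1ccccc1C(=O)O[C@H]1CO[C@H]2[C@@H]1OC[C@H]2OC(=O)c1snnc1C`, gives 0.0065 h in an ADME assay on a cell-free system (plasma, Homo sapiens) for metabolic stability, with Plasma (Rattus norvegicus) as the target, read by HPLC, at pH 7.4; on this read-out higher numbers stand for a longer-lived compound and lower numbers for a shorter-lived compound.
Compound 2, `CC(=O)Oc1ccccc1C(=O)O[C@H]1CO[C@H]2[C@@H]1OC[C@H]2OC(=O)c1ccc(C)cc1`, gives 0.0362 h in this assay.
Compound 3, `CC(=O)Oc1ccccc1C(=O)O[C@H]1CO[C@H]2[C@@H]1OC[C@H]2OC(=O)CO[N+](=O)[O-]`, gives 0.015 h in this assay.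

Compound 2 is the longest-lived of the three: the step from compound 1 is a 5.6-fold higher number from compound 1 to compound 2 (0.75 log units; beyond the scatter), and the change from compound 2 to compound 3 is a 2.4-fold lower number from compound 2 to compound 3 (0.38 log units; beyond the scatter). The step of a 2.3-fold higher number from compound 1 to compound 3 (0.36 log units; beyond the scatter) completes the set.

Compound 4, `CC(=O)Oc1ccccc1C(=O)O[C@H]1CO[C@H]2[C@@H]1OC[C@H]2OC(=O)c1ccccc1CO[N+](=O)[O-]`, has not yet been measured. It differs from compound 2 in one place: 2-((nitrooxy)methyl)phenyl in place of 4-methylphenyl on a carbonyl carbon.

The closest guide is the step from compound 2 to compound 3, a 2.4-fold lower number from compound 2 to compound 3 (0.38 log units; beyond the scatter), where the whole aromatic ring gave way to a (nitrooxy)methyl group. In compound 4 the ring remains and the (nitrooxy)methyl group is added on it, so a smaller shift than that is expected, most likely one within the usual scatter. Compound 4 is therefore expected to show a 1.2-fold lower number from compound 2 to compound 4 (0.08 log units; within the scatter), with a half-life estimated at 0.03 h, between 0.012 h and 0.08 h.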

Compound 4, half-life: 0.0533 h
Estimate against measurement, compound 4: 1.8-fold (0.25 log units) below; measured number inside the range.
By their numbers in this assay, from the lowest: compound 1; then compound 3; then compounds 2 and 4 (each within the scatter of the next).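

Placing 2-((nitrooxy)methyl)phenyl on this carbonyl carbon instead of 4-methylphenyl gives a 1.5-fold higher number from compound 2 to compound 4 (0.17 log units; within the scatter) in this assay, so the larger group brings no readable change in half-life here. Compound 3 had left open whether a nitrooxy group itself goes with a shorter life, but with the six-membered aromatic ring kept, the picture differs: the new compound shows a 3.6-fold higher number from compound 3 to compound 4 (0.55 log units; beyond the scatter), and also an 8.2-fold higher number from compound 1 to compound 4 (0.91 log units; beyond the scatter). Nothing shown gives a reason for these differences.

Still open, going by these compounds, is how far the result depends on the link between the ring and the nitrooxy group, which a longer chain, such as a (nitrooxy)ethyl group, could test. It is also unknown whether a different group on the ring, such as an amine or a carboxylic acid, would leave the half-life as unchanged.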